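The source may hold more compounds than are shown below. What is called first, only, known or untested is meant among the compounds shown, and "the series" means these compounds.

Measured compounds:
- compound 1, `Cc1ccc(NC(=S)NC(=O)c2ccc(OCc3ccccc3F)cc2)cc1-c1nc2ccccc2[nH]1`: in a functional assay on MGC-803 cells (Homo sapiens) for inhibition, read by MTT assay, with a stated time of 48 h (a higher number here means a weaker inhibitor, a lower number a stronger inhibitor), compound 1 gives 3070 nM.
- compound 2, `Cc1ccc(NC(=S)NC(=O)c2ccc(OCc3cccc(Cl)c3Cl)cc2)cc1-c1nc2ccccc2[nH]1`: in this assay compound 2 reaches only a limit of the assay, not a number, > 100000 nM.
- compound 3, `Cc1ccc(NC(=S)NC(=O)c2ccc(OCc3ccc(Cl)cc3Cl)cc2)cc1-c1nc2ccccc2[nH]1`: in this assay compound 3 gives 3450 nM.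

Compound 3 carries the highest of the two numbers, but its nearest neighbour is compound 1, and the step of a 1.1-fold higher number from compound 1 to compound 3 (0.05 log units; within the scatter) sits within the scatter, so the two are not ordered. Compound 2 stands apart at the limit (the limit of > 100000 nM in this assay, at which 1 of the 3 values shown sits); the steps of an at least 32-fold higher number from compound 1 to compound 2 (1.51 log units; beyond the scatter) and an at least 28-fold lower number from compound 2 to compound 3 (1.46 log units; beyond the scatter) are both large.

Compound 4, `Cc1ccc(NC(=S)NC(=O)c2ccc(OCc3ccc(F)cc3)cc2)cc1-c1nc2ccccc2[nH]1`, differs from compound 3 by 4-fluorophenyl in place of 2,4-dichlorophenyl on a saturated chain carbon bound to an oxygen on an aromatic ring. Among the measured compounds shown here, the only measured step that touches a fluorophenyl, a 1.1-fold higher number from compound 1 to compound 3 (0.05 log units; within the scatter), is within the scatter, and no measured step places a fluorine at the position entering here; the large steps above concern the 2,3-dichlorophenyl only. The expected step of a 1.1-fold lower number from compound 3 to compound 4 (0.03 log units; within the scatter) is therefore small, with no direction beyond the scatter. Compound 4 is expected to give about 3200 nM, estimated between 1000 nM and 15000 nM.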

Compound 4, half-maximal inhibitory concentration: 2810 nM
Estimate against measurement, compound 4: 1.1-fold (0.06 log units) above, and the stated range covers the measured number.
By their numbers in this assay, from the lowest: compounds 4, 1 and 3 (each within the scatter of the next). At a limit, above all of these: compound 2.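

Here the 4-fluorophenyl joins the 2-fluorophenyl and the 2,4-dichlorophenyl on the same level: a 1.2-fold lower number from compound 3 to compound 4 (0.09 log units; within the scatter) and a 1.1-fold lower number from compound 1 to compound 4 (0.04 log units; within the scatter) are both within the scatter, so neither the place of the single fluorine nor the exchange of two chlorines for one fluorine gives an order among compounds 1, 3 and 4. Against this flat set the 2,3-dichlorophenyl of compound 2 stands alone, now also in an at least 35-fold lower number from compound 2 to compound 4 (1.55 log units; beyond the scatter), and it is the one exception among the four compounds. The value of compound 2 is a limit of the assay, not a number: the limit of > 100000 nM in this assay, at which 1 of the 4 values shown sits.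

Still open, on these data alone, is whether the break belongs to the 2,3-dichlorophenyl alone or would recur with other rings on this chain carbon. An unsubstituted phenyl, a pyridine ring, a carboxylic acid or a longer chain in place of the benzyl would test how far the flat level extends.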